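Shortening the Amide Substituent to Propyl: Expected Outcome

The source may report more compounds than this note shows. Statements on the series, on what has been measured and on what is new or still open speak of the compounds shown alone.

Compound 1, `C=CC1=C(C(=O)NCC(C)C)C(c2ccc(OC)cc2)OC1`: > 100000 nM
Compound 2, `C=CC1=C(C(=O)Nc2ccc(OCC)cc2)C(c2ccc(OC)cc2)OC1`: > 100000 nM

In a functional assay on QGY7701 cells (Homo sapiens) for cytotoxicity, read by MTT assay, with a stated time of 24 h (on this read-out lower numbers stand for stronger inhibition and higher numbers for weaker inhibition), compound 1 gives only a limit, > 100000 nM. In this assay compound 2 also gives only a limit, > 100000 nM. Compound 2 thus stands at the edge of what this assay can report, as the limit of > 100000 nM in this assay, at which 2 of the 2 values shown sit, shows. Compound 3, `C=CC1=C(C(=O)NCCC)C(c2ccc(OC)cc2)OC1`, differs from compound 2 by propyl in place of 4-ethoxyphenyl on an amide-type nitrogen. Within the data shown here, the only measured step is a step that the two limits leave unreadable from compound 1 to compound 2; it cannot be read because the limit of > 100000 nM in this assay, at which 2 of the 2 values shown sit, holds both of its ends. No direction or size beyond the scatter can therefore be expected in this assay. Compound 3 is expected to stay at the limit, estimated at 150000 nM (range 80000 nM to 400000 nM). The expected step that the limit leaves unreadable from compound 2 to compound 3 is likewise expected to carry no readable size.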

Compound 3, half-maximal inhibitory concentration: > 100000 nM
Compound 3 ended at the assay's limit; the forecaster's own chance of this, stated with the estimate: 85%; the middle value does not contradict the limit.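

No step among compound 1, compound 2 and compound 3 can be read, because all three give only a limit, not a number: the limit of > 100000 nM in this assay, at which 3 of the 3 values shown sit.

Going by these compounds, whether the group on the amide nitrogen changes the result in this assay at all stays open.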